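A few compounds are considered here, and "the series" means these few. Any claim that something is new, unique, unknown or untested is made for them only; others in the source may bear on it.

The study concerns three measured compounds and one yet to be tested, all read in a functional assay on KYSE-410 cells (Homo sapiens) for antiproliferative activity, read by MTT assay, with a stated time of 72 h; on this read-out higher numbers stand for weaker inhibition and lower numbers for stronger inhibition. Compound 1 `O=C(c1cc(=O)[nH]c2cc(Br)ccc12)N1CCCCC1` gives a value that is a limit of the assay rather than a number, > 20000 nM. Compound 2 `COc1cccc(NC(=O)c2cc(=O)[nH]c3cc(Br)ccc23)c1` likewise gives only a limit, > 20000 nM. Compound 3 `CC(=O)c1ccc(-c2ccc3c(C(=O)Nc4cccc(F)c4)cc(=O)[nH]c3c2)cc1` also sits at a limit, > 20000 nM. On the numbers shown, compound 3 therefore stands nowhere above or below its neighbours: all three rest on the same boundary, as summed up by the limit of > 20000 nM in this assay, at which 3 of the 3 values shown sit.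

The next compound, compound 4 `C=Cc1ccc2c(C(=O)Nc3cccc(F)c3)cc(=O)[nH]c2c1`, has not been measured. It differs from compound 3 by vinyl in place of 4-acetylphenyl on an aromatic carbon. With every measured value a limit, no step between measured compounds can be read, and the data give no reason to expect a move beyond the scatter in either direction. The step from compound 3 to compound 4 is estimated as a step that the limit leaves unreadable from compound 3 to compound 4. Compound 4 is expected to give about 30000 nM, most likely again reported as a limit, within a range of 8000 nM to 120000 nM.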

Compound 4, half-maximal inhibitory concentration: 13600 nM
For compound 4 the middle estimate is 2.2-fold (0.34 log units) above the measured one; measured number inside the range.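

In this assay, vinyl in place of 4-acetylphenyl on this aromatic carbon gives an at least 1.4-fold lower number from compound 3 to compound 4 (0.16 log units; that floor lies within the scatter). Compound 4 is the first compound shown whose value is a number rather than a limit, so a reading at this position does not require the aromatic ring or the carbonyl of 4-acetylphenyl. Compound 3 still holds only a limit, so the true size of the step cannot be read and only its floor is known: the limit of > 20000 nM in this assay, at which 3 of the 4 values shown sit.

From the compounds shown here alone, whether an ethyl group, a longer chain, an amine or a carboxylic acid on this carbon would give a lower number than vinyl stays open. The compounds shown also leave open whether the double bond of vinyl matters for the reading in compound 4.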